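This account rests on a few compounds, and the source may have more. Where it says the series, first, only, none or still open, it means among the compounds named here.

Series notes, hormone-sensitive lipase inhibitors sharing the core of compound 1.

In an assay (strain Wistar) for inhibition of Hormone-sensitive lipase (Rattus norvegicus), read by spectrophotometry (on this read-out lower numbers stand for stronger inhibition and higher numbers for weaker inhibition), compound 1 `Cc1c(C(C)C)c(=O)on1C(=O)N1CCCCC1` gives 2 nM. Compound 2 `Cc1c(C(C)C)c(=O)on1C(=O)N(C)Cc1ccc(F)cc1` gives 111 nM in this assay, the highest of the two numbers recorded so far; the gap to compound 1 runs well beyond the scatter, though the two structures differ in more than one place, so no single step can be read from that pair.

Compound 3 `Cc1c(C(C)C)c(=O)on1C(=O)N(C)Cc1ccco1` is the next analogue for this assay. It differs from compound 2 by furan-2-yl in place of 4-fluorophenyl on a saturated chain carbon bound to an amide-type nitrogen. With no measured step of this kind in the set, the change is expected to give a step of a 1.4-fold higher number from compound 2 to compound 3 (0.13 log units; within the scatter), which would not reach beyond the scatter in either direction. On that basis compound 3 is estimated at 150 nM in this assay, with a plausible range of 40 nM to 600 nM pending the actual measurement.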

Compound 3, half-maximal inhibitory concentration: 4 nM
Compound 3: middle estimate off by 38-fold (1.57 log units), on the high side; measured number below the stated range.
By their numbers in this assay, from the lowest: compounds 1 and 3 (each within the scatter of the next); then compound 2.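

In this assay, the group on a saturated chain carbon bound to an amide-type nitrogen proves to be a position that strongly affects the read-out: furan-2-yl in place of 4-fluorophenyl gives a 28-fold lower number from compound 2 to compound 3 (1.44 log units; beyond the scatter), a large step beyond the scatter. For the compounds shown here, compound 1 and compound 2 differ in more than one place and could not isolate this position, so this is the first single-place step and shows that the swap of one aromatic ring for the other is enough to move the number substantially. Nothing measured in the series accounts for the size of this step.

Open, going by these compounds, is whether plain phenyl, without the fluorine, or thiophen-2-yl on the same carbon would give a number close to that of compound 3 or to that of compound 2. Also open, on these data alone, is whether a longer chain between the amide-type nitrogen and the furan-2-yl group would preserve the lower number.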